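Swapping an Amide-Type Group for a Thiophene Ring

A few compounds are considered here, and "the series" means these few. Any claim that something is new, unique, unknown or untested is made for them only; others in the source may bear on it.

Of the compounds shown here, three sharing one core have been measured in an ADME assay on Caco-2 cells (Homo sapiens) for permeability, in the apical to basolateral direction; on this read-out higher numbers stand for higher permeability and lower numbers for lower permeability. Compound 1 `Cn1cncc1CN1CC(N(CC2CCN(C(=O)Nc3ccc(Br)cc3)CC2)S(=O)(=O)c2ccccn2)Cc2cc(C#N)ccc21` gives 0.6 10^-6 cm/s, compound 2 `Cn1cncc1CN1CC(N(CC2CCN(C(=O)NC(C)(C)C)CC2)S(=O)(=O)c2ccccn2)Cc2cc(C#N)ccc21` gives 0.6 10^-6 cm/s, and compound 3 `CC(C)OC(=O)N1CCC(CN(C2Cc3cc(C#N)ccc3N(Cc3cncn3C)C2)S(=O)(=O)c2ccccn2)CC1` gives 1 10^-6 cm/s. Compound 2 therefore stands level with compound 1, together at the lowest of the three numbers, with compound 3 as the furthest: a 1.7-fold higher number from compound 2 to compound 3 (0.22 log units; within the scatter). The step from compound 1 to compound 2 shows no change at the digits printed from compound 1 to compound 2 (within the scatter).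

Compound 4 `Cn1cncc1CN1CC(N(CC2CCN(C(=O)c3cccs3)CC2)S(=O)(=O)c2ccccn2)Cc2cc(C#N)ccc21` differs from compound 2 by a single change, (thiophen-2-yl in place of (tert-butyl)amino on a carbonyl carbon). Among the compounds with values here, the steps that bear on it, from compound 1 to compound 2 and from compound 2 to compound 3, both stayed within the scatter, so the expected step is a 1.5-fold higher number from compound 2 to compound 4 (0.18 log units; within the scatter), with no change beyond the scatter foreseen. Compound 4 is thus estimated at 0.9 10^-6 cm/s, within the range 0.4 10^-6 cm/s to 2 10^-6 cm/s.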

Compound 4, apparent permeability: 0.5 10^-6 cm/s
The estimate for compound 4 lay 1.8-fold (0.26 log units) above the measured number, and the stated range covers the measured number.
By their numbers in this assay, from the lowest: compounds 4, 1, 2 and 3 (each within the scatter of the next).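

Putting thiophen-2-yl on this carbonyl carbon takes away the hydrogen-bond donor of (tert-butyl)amino, yet this assay gives a 1.2-fold lower number from compound 2 to compound 4 (0.08 log units; within the scatter) as the result. The other two comparisons at this place read the same way, with a 1.2-fold lower number from compound 1 to compound 4 (0.08 log units; within the scatter) and a 2.0-fold lower number from compound 3 to compound 4 (0.30 log units; within the scatter) as the result, so a ring joined directly to the carbonyl carbon also stays within the scatter of the groups before it. No measurement here gives a cause for these small steps. On these data alone, whether a carboxylic acid or a longer chain ending in an amine at this place would give a step beyond the scatter remains open.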